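Chloropyridinyl amide swap transferred to the second core

The source may report more compounds than this note shows. Statements on the series, on what has been measured and on what is new or still open speak of the compounds shown alone.

Compound 1 `Cc1noc(C)c1-c1cnc(N)c(Oc2ccc(C(=O)Nc3cccc(Cl)n3)cc2)n1` gives 64100 nM in a functional assay on U-87MG ATCC cells for inhibition, with U-87 MG (Homo sapiens) as the target, read by MTT assay, with a stated time of 72 h; on this read-out higher numbers stand for weaker inhibition and lower numbers for stronger inhibition. Compound 2 `Cc1noc(C)c1-c1cnc(N)c(Oc2ccc(C(=O)Nc3ccc(Cl)cn3)cc2)n1` gives 45600 nM in this assay; it differs from compound 1 by 5-chloropyridin-2-yl in place of 6-chloropyridin-2-yl on an amide-type nitrogen, and that change made a 1.4-fold lower number from compound 1 to compound 2 (0.15 log units; within the scatter). Compound 3 `Cn1cc(-c2cnc(N)c(Oc3ccc(C(=O)Nc4cccc(Cl)n4)cc3)n2)cn1` gives 54800 nM in this assay; its core differs from that of compound 1 by 1-methyl-1H-pyrazol-4-yl in place of 3,5-dimethyl-1,2-oxazol-4-yl on an aromatic carbon, a step of a 1.2-fold lower number from compound 1 to compound 3 (0.07 log units; within the scatter). Compound 4 `Cn1cc(-c2cnc(N)c(Oc3ccc(C(=O)Nc4ccc(Cl)cn4)cc3)n2)cn1` is not yet measured. It differs from compound 3 by 5-chloropyridin-2-yl in place of 6-chloropyridin-2-yl on an amide-type nitrogen, the same change as that between compound 1 and compound 2, at a place described in identical words. For compound 4 a step of a 1.4-fold lower number from compound 3 to compound 4 (0.14 log units; within the scatter) is expected, resting on the step of a 1.4-fold lower number from compound 1 to compound 2 (0.15 log units; within the scatter) seen on the other core. Compound 4 is therefore estimated at 40000 nM, with a range from 20000 nM to 80000 nM in this assay.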

Compound 4, half-maximal inhibitory concentration: 22200 nM
Compound 4: middle estimate off by 1.8-fold (0.26 log units), on the high side; low and high end bracket the measured number.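

In this assay, 5-chloropyridin-2-yl in place of 6-chloropyridin-2-yl on the amide-type nitrogen gives a 2.5-fold lower number from compound 3 to compound 4 (0.39 log units; beyond the scatter), and this step agrees with the one on the other core: the same change on two cores in this assay, a 1.4-fold lower number (0.15 log units; within the scatter) from compound 1 to compound 2 and a 2.5-fold lower number (0.39 log units; beyond the scatter) from compound 3 to compound 4, 1.8-fold (0.24 log units) apart, within the scatter of two such steps. With the 5-chloropyridin-2-yl amide held constant, 1-methyl-1H-pyrazol-4-yl in place of 3,5-dimethyl-1,2-oxazol-4-yl gives a 2.1-fold lower number from compound 2 to compound 4 (0.31 log units; beyond the scatter), which likewise agrees with its earlier counterpart: the same change on two cores in this assay, a 1.2-fold lower number (0.07 log units; within the scatter) from compound 1 to compound 3 and a 2.1-fold lower number (0.31 log units; beyond the scatter) from compound 2 to compound 4, 1.8-fold (0.24 log units) apart, within the scatter of two such steps. Both changes therefore show no detectable dependence on their partner group, but a single pair of each cannot show that the steps are equal in size, and each earlier step lies within the scatter.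

As far as these compounds go, whether a nitrile or a methyl group in place of the chlorine would follow the same pattern stays open. So does the effect of an amine or a carboxylic acid on the pyridine ring.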